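This account rests on a few compounds, and the source may have more. Where it says the series, first, only, none or still open, it means among the compounds named here.

Measured in an ADME assay on a cell-free system (plasma, Mus musculus) for metabolic stability, tested at 1 uM; a lower number here means that the compound disappears faster, a higher number that the compound lasts longer:

- Compound 1 `C=CC(=O)NCC1CCN(S(=O)(=O)c2ccc(NC(=O)OCc3ccccc3)cc2)CC1`: > 6 h
- Compound 2 `C=CC(=O)N[C@H]1CCCN(S(=O)(=O)c2ccc(NC(=O)OCc3ccccc3)cc2)C1`: > 6 h
- Compound 3 `C=CC(=O)NC1CCN(S(=O)(=O)c2ccc(C(=O)NCc3ccccc3)cc2)CC1`: > 6 h

Each entry here is a limit of the assay and not a number. The set as a whole shows (the limit of > 6 h in this assay, at which 3 of the 3 values shown sit). Going by these compounds, compound 3 therefore has no exact place on the scale, and the true half-life of compound 3 remains unknown.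

The next compound to consider is compound 4 `C=CC(=O)NC1CCN(S(=O)(=O)c2ccc(C(=O)NCCC3CCCCC3)cc2)CC1`, which differs from compound 3 at the far end of the amide: cyclohexylmethyl in place of phenyl on a saturated chain carbon bound to an amide-type nitrogen. In words, this places cyclohexylmethyl in place of phenyl on a saturated chain carbon bound to an amide-type nitrogen. The same difference can also be read as benzyl to 2-cyclohexylethyl.

For the measured compounds named here, no two measured compounds differ in one place only, so no measured step gives a size for this change. Going by the values given here, the only guide is that all three measured compounds reach the same limit. No change beyond the usual scatter is expected, and neither direction is favoured. The expected change is a step that the limit leaves unreadable from compound 3 to compound 4. Another report of a limit is the likeliest outcome. In this assay, the estimated half-life for compound 4 is 7 h, with an expected range of 4 h to 12 h.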

Compound 4, half-life: > 6 h
Compound 4 gave a limit, no number; the forecaster's own chance of this, stated with the estimate: 80%; the middle value is on the limit's open side.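

For the compounds shown here, compound 3 and compound 4 each give only a limit in this assay, so no step from one to the other can be read, and the size of the change from phenyl to cyclohexylmethyl stays unknown. All the values shown share one ceiling: the limit of > 6 h in this assay, at which 4 of the 4 values shown sit. The compounds shown leave open the true half-life of each one and whether any of these structural differences alters it.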